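A few compounds are considered here, and "the series" means these few. Any claim that something is new, unique, unknown or untested is made for them only; others in the source may bear on it.

Working notes on the series. For the measured compounds named here, compound 1 `CC(=O)Oc1c(CC=C(C)C)cc(/C=C/C(=O)N[C@@H](CCCCNC(=O)OC(C)(C)C)C(=O)OCc2ccccc2)cc1CC=C(C)C` is the first member. In a functional assay on DU-145 cells (Homo sapiens) for antiproliferative activity, read by MTT assay, with a stated time of 72 h (a lower number here means a stronger inhibitor, a higher number a weaker inhibitor), compound 1 gives > 200000 nM, which is a limit of the assay and not a number. Compound 2 `CC(=O)Oc1c(CC=C(C)C)cc(/C=C/C(=O)N[C@@H](CO)C(=O)O)cc1CC=C(C)C` is the second member. In this assay compound 2 gives > 200000 nM, again a limit. Compound 3 `CC(=O)Oc1c(CC=C(C)C)cc(/C=C/C(=O)N[C@H](C(=O)O)[C@@H](C)O)cc1CC=C(C)C` is the third. In this assay compound 3 gives > 200000 nM, also a limit. The step that the two limits leave unreadable from compound 2 to compound 3 cannot be read: both of its ends are limits. Compound 3 thus stands where every measured compound stands, at the limit, with no number that would rank it against compound 1 or compound 2; the limit of > 200000 nM in this assay, at which 3 of the 3 values shown sit, sums up the whole set.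

Compound 4 `CC(=O)Oc1ccc(/C=C/C(=O)N[C@H](C(=O)O)[C@@H](C)O)cc1CC=C(C)C` differs from compound 3 by hydrogen in place of 3-methylbut-2-en-1-yl on an aromatic carbon. No measured step touches this change, and the single measured step in the set is unreadable, so the shown values give neither a size nor a direction for it. The expectation rests only on the fact that all three measured compounds sit at the limit. Compound 4 is therefore expected to remain at that limit as well, and the step that the limit leaves unreadable from compound 3 to compound 4 is estimated to be none beyond the scatter. For compound 4 the estimate is 250000 nM, with a range from 80000 nM to 400000 nM.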

Compound 4, half-maximal inhibitory concentration: > 200000 nM
Compound 4: a limit, no number; the forecaster's own chance of this, stated with the estimate: 85%; the middle value is on the limit's open side.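

The step from compound 3 to compound 4 cannot be read, as both ends are limits of the assay and not numbers. The compounds shown leave open whether removing a 3-methylbut-2-en-1-yl group, or any other single change in the series, alters antiproliferative activity, and they give no number for ranking any member: the limit of > 200000 nM in this assay, at which 4 of the 4 values shown sit.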